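This account rests on a few compounds, and the source may have more. Where it says the series, first, only, none or still open, it means among the compounds named here.

Compound 1 `COc1ccc(-c2nc(C)c(C(=O)CSc3nc(-c4ccc(OC)c(OC)c4)c(C#N)c(=O)[nH]3)s2)cc1`, compound 2 `Cc1nc(-c2ccc(Cl)cc2)sc1C(=O)CSc1nc(-c2cccc(Cl)c2)c(C#N)c(=O)[nH]1` and compound 3 `COc1ccc(-c2nc(SCC(=O)c3sc(-c4ccccc4)nc3C)[nH]c(=O)c2C#N)cc1OC` have each been tested in a functional assay on U-87MG ATCC cells for antiproliferative activity against U-87 MG (Homo sapiens), read by MTT assay, with a stated time of 48 h, tested at 100 uM; a higher number here means a weaker effect of the compound at the concentration tested, a lower number a stronger effect. In this assay compound 1 gives 5.39% and compound 3 gives 6.48%. Compound 3 stands second highest of the three numbers, yet its gap to compound 1 and its gap to compound 2 both lie within the usual scatter of such measurements, so no order among the three can be read from them. Within the data shown here, the only step between measured compounds that differ in one place is a number 1.1 percentage points higher from compound 1 to compound 3 (within the scatter), and it does not rise above the scatter.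

Compound 4 `COc1ccc(-c2nc(SCC(=O)c3sc(-c4ccc(Cl)cc4)nc3C)[nH]c(=O)c2C#N)cc1OC` has not yet been measured. It differs from compound 3 by chloro in place of hydrogen on an aromatic carbon. Compound 2 also carries a chloro group on a phenyl ring, but it differs from compound 3 in more than one place, so its reading in this assay, where compound 2 gives 12.5%, can only be noted, not used as a step. Because a number 1.1 percentage points higher from compound 1 to compound 3 (within the scatter) stayed within the scatter, the step of a number 1.5 percentage points higher from compound 3 to compound 4 (within the scatter) is expected to be small, with at most a slight rise. Compound 4 is therefore estimated at 8%, in a range from 3% to 16%.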

Compound 4, a percentage reported as activity, at one concentration (the size of the read-out at that concentration, not a potency): 18.7%
Compound 4: the middle estimate sits 10.7 percentage points below what was measured; the whole stated range lies below it.
By their numbers in this assay, from the lowest: compounds 1, 3, 2 and 4 (each within the scatter of the next, the first and the last beyond it).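

In this assay, the phenyl to 4-chlorophenyl change gives a number 12.2 percentage points higher from compound 3 to compound 4 (beyond the scatter) and so moves the reading beyond the scatter, which the earlier step between compound 1 and compound 3 did not do; at this place, para to a large group, the modest shift points to a weaker effect at the concentration tested. Chloro in place of methoxy at the same place gives a number 13.3 percentage points higher from compound 1 to compound 4 (beyond the scatter) and also lies beyond the scatter, so among the three groups seen here, hydrogen and methoxy cannot be told apart, while chloro stands apart from both. With the 4-chlorophenyl group kept and 3,4-dimethoxyphenyl in place of 3-chlorophenyl on the other side of the molecule, the result is a number 6.2 percentage points higher from compound 2 to compound 4 (within the scatter) and no difference can be read from that exchange.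

Nothing in the data shown explains why chloro at this place weakens the effect. As far as these compounds go, it also remains open how an amine, a carboxylic acid or a longer chain at the same place would read, and whether a chloro group elsewhere on this phenyl ring would give a similar shift.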